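Notes on compound 4, a ring-isomer of compound 3

This account rests on a few compounds, and the source may have more. Where it says the series, first, only, none or still open, it means among the compounds named here.

Measured in a functional assay on 1321-N1 cells for agonist activity at P2Y purinoceptor 6 (Homo sapiens), read by scintillation counting and inositol phosphate accumulation; a lower number here means that less compound is needed, a higher number that more compound is needed for the effect:
- compound 1 `O=C(O)CCCO/N=c1/ccn([C@@H]2O[C@H](COP(=O)(O)OP(=O)(O)OP(=O)(O)O)[C@@H](O)[C@H]2O)c(=O)[nH]1`: 697 nM
- compound 2 `O=c1[nH]/c(=N\OCCOc2ccccc2)ccn1[C@@H]1O[C@H](COP(=O)(O)OP(=O)(O)OP(=O)(O)O)[C@@H](O)[C@H]1O`: 1780 nM
- compound 3 `O=c1[nH]/c(=N\OCCCc2cccc(I)c2)ccn1[C@@H]1O[C@H](COP(=O)(O)OP(=O)(O)OP(=O)(O)O)[C@@H](O)[C@H]1O`: 299 nM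

Compound 3 stands lowest of the three numbers in this assay, and both gaps lie beyond the scatter: a 2.3-fold lower number from compound 1 to compound 3 (0.37 log units; beyond the scatter) and a 6.0-fold lower number from compound 2 to compound 3 (0.77 log units; beyond the scatter). The phenoxy analogue sits highest, as a 2.6-fold higher number from compound 1 to compound 2 (0.41 log units; beyond the scatter) shows.

Compound 4 `O=c1[nH]/c(=N\OCCCc2ccc(I)cc2)ccn1[C@@H]1O[C@H](COP(=O)(O)OP(=O)(O)OP(=O)(O)O)[C@@H](O)[C@H]1O` keeps the same atoms as compound 3 and differs only in how they are joined: 4-iodophenyl in place of 3-iodophenyl on a saturated chain carbon, three bonds along the chain from an oxygen. For the measured compounds named here, none of the measured steps moves the iodine around the ring; the steps into compound 3 only show that placing the iodobenzyl chain there lowers the number relative to the carboxy and phenoxy chains. The data therefore give no direction for this change. The expectation for compound 4 in this assay is a step of about a 1.3-fold higher number from compound 3 to compound 4 (0.13 log units; within the scatter), which is treated as within the scatter. Compound 4 is estimated at 400 nM, with a range from 150 nM to 1200 nM.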

Compound 4, half-maximal effective concentration: 90 nM
Beside the measured number, compound 4's estimate is 4.4-fold (0.65 log units) above it, and the stated range ends above it.
By their numbers in this assay, from the lowest: compound 4; then compound 3; then compound 1; then compound 2.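

In this assay, for the compounds shown here, moving the iodine is not a neutral change: a 3.3-fold lower number from compound 3 to compound 4 (0.52 log units; beyond the scatter), the first measured step that alters only where the iodine sits on the ring, so the outcome depends on the 4-iodophenyl arrangement and not merely on the presence of an iodobenzyl chain. Going by these compounds alone, the 4-iodobenzyl chain also widens the separation from the other chains, with a 7.7-fold lower number from compound 1 to compound 4 (0.89 log units; beyond the scatter) and a 20-fold lower number from compound 2 to compound 4 (1.30 log units; beyond the scatter), the latter being the only large step. Nothing available explains why the 4-iodophenyl isomer gives the lower number.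

Open, on these data alone, is whether bromine or chlorine in place of the iodine would keep this lower number. Also open, as far as these compounds go, is whether a longer chain carrying the 4-iodophenyl group would hold it.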